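A few compounds are considered here, and "the series" means these few. Any claim that something is new, unique, unknown or untested is made for them only; others in the source may bear on it.

Working notes on the series. Within the data shown here, compound 3 `CCCc1nc(-c2ccccc2)c(CNCCCN2CCN(c3cccc(C(F)(F)F)c3)CC2)o1` gives 650 nM in an assay on HEK293 cells for inhibition of Voltage-dependent T-type calcium channel subunit alpha-1G (Homo sapiens), read by patch clamp (on this read-out higher numbers stand for weaker inhibition and lower numbers for stronger inhibition), the lowest of the three numbers measured so far. Its nearest neighbour is compound 1 `CCCc1nc(-c2ccccc2)c(CNCCCN2CCN(c3cccc(C)c3)CC2)o1`, which gives 1190 nM; the gap between the two lies within the scatter. The furthest is compound 2 `CCCc1nc(-c2ccccc2)c(CNCCCN2CCN(c3ccc(C(F)(F)F)cc3)CC2)o1`, which gives 7250 nM; the step of an 11-fold lower number from compound 2 to compound 3 (1.05 log units; beyond the scatter) is a large one.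

Compound 4 `CCCc1nc(-c2ccccc2)c(CNCCCN2CCN(c3ccc(Cl)cc3)CC2)o1` is not yet measured. It differs from compound 3 by 4-chlorophenyl in place of 3-(trifluoromethyl)phenyl on an amine nitrogen in a ring.

Among the measured compounds shown here, two measured steps bear on this. Moving from a 4-(trifluoromethyl)phenyl to a 3-(trifluoromethyl)phenyl gave an 11-fold lower number from compound 2 to compound 3 (1.05 log units; beyond the scatter); moving from 3-methylphenyl to 4-(trifluoromethyl)phenyl gave a 6.1-fold higher number from compound 1 to compound 2 (0.78 log units; beyond the scatter). Both place the 4-(trifluoromethyl)phenyl of compound 2 at the weak end. For the measured compounds named here, compound 4 carries a 4-chlorophenyl, which is nearer in kind to the group of compound 2 than to that of compound 3, though chloro is not trifluoromethyl and no step with chloro exists here. A higher number than compound 3 is therefore expected, smaller than the step seen in compound 2, giving an expected step of a 4.6-fold higher number from compound 3 to compound 4 (0.66 log units; beyond the scatter). Compound 4 is estimated at 3000 nM, within a range of 1200 nM to 8000 nM.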

Compound 4, half-maximal inhibitory concentration: 1310 nM
Compound 4: middle estimate off by 2.3-fold (0.36 log units), on the high side; measured number inside the range.
By their numbers in this assay, from the lowest: compounds 3, 1 and 4 (each within the scatter of the next); then compound 2.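

In this assay, the weak result of compound 2 does not extend to every 4-substituted phenyl among those shown: chloro in place of trifluoromethyl on an aromatic carbon gives a 5.5-fold lower number from compound 2 to compound 4 (0.74 log units; beyond the scatter), so at this position the outcome depends on the group carried by the phenyl as well as on where it stands. The 4-chlorophenyl cannot be separated from the other two groups, with a 2.0-fold higher number from compound 3 to compound 4 (0.30 log units; within the scatter) and a 1.1-fold higher number from compound 1 to compound 4 (0.04 log units; within the scatter), so compounds 1, 3 and 4 form one group in this read-out, with only the 4-(trifluoromethyl)phenyl of compound 2 standing apart from compound 3 and compound 4. No measurement shown here accounts for the difference between the chloro and trifluoromethyl groups.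

From the compounds shown here alone, it remains open what a 3-chlorophenyl or an unsubstituted phenyl would give on the same amine nitrogen in a ring, and so whether the gap seen between the two trifluoromethyl isomers recurs with chloro. Going by these compounds, whether these steps hold with a longer chain in place of the propyl on the shared core also remains open.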